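Notes on the triazolyl to imidazolyl change from compound 2

The source may report more compounds than this note shows. Statements on the series, on what has been measured and on what is new or still open speak of the compounds shown alone.

Measured so far:
compound 1, `CN(C)c1ccc(C2CC(c3ccc(-n4cncn4)cc3)=NN2C(=O)c2ccc(C(F)(F)F)cc2)cc1`, gives 11.5% in a functional assay on NCI-H1975 cells (Homo sapiens) for inhibition, read by sulforhodamine B assay, tested at 10 uM; on this read-out lower numbers stand for less inhibition and higher numbers for more inhibition at the one concentration tested (going by the name of the read-out)
compound 2, `Cc1ccc(S(=O)(=O)N2N=C(c3ccc(-n4cncn4)cc3)CC2c2ccc(N(C)C)cc2)cc1`, gives 20% in this assay
compound 3, `CN(C)c1ccc(C2CC(c3ccc(-n4cncn4)cc3)=NN2S(=O)(=O)c2ccc(Br)cc2)cc1`, gives -0.6% in this assay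

Compound 2 has the highest of the three numbers, though compound 1 sits within the scatter of it (a number 8.5 percentage points higher from compound 1 to compound 2 (within the scatter)), while compound 3 lies beyond it (a number 20.6 percentage points lower from compound 2 to compound 3 (beyond the scatter)). Compound 4, `Cc1ccc(S(=O)(=O)N2N=C(c3ccc(-n4ccnc4)cc3)CC2c2ccc(N(C)C)cc2)cc1`, differs from compound 2 in one place: 1H-imidazol-1-yl in place of 1H-1,2,4-triazol-1-yl on an aromatic carbon. For the measured compounds named here, none of the measured steps touches this ring; they concern the group on the ring nitrogen (a number 12.1 percentage points lower from compound 1 to compound 3 (beyond the scatter)) or the methyl and bromo there. Going by the values given here, no measured step therefore bears on this change, and the expectation is a step no larger than the scatter, a number 1 percentage points lower from compound 2 to compound 4 (within the scatter). For compound 4 the estimate is 19%, with a range from 4% to 34%.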

Compound 4, a percentage reported as inhibition, at one concentration (the size of the read-out at that concentration, not a potency): 50.5%
Compound 4: the middle estimate sits 31.5 percentage points below what was measured; measured number above the stated range.
By their numbers in this assay, from the lowest: compound 3; then compounds 1 and 2 (each within the scatter of the next); then compound 4.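

The change from 4-(1H-1,2,4-triazol-1-yl)phenyl to 4-(1H-imidazol-1-yl)phenyl gives a number 30.5 percentage points higher from compound 2 to compound 4 (beyond the scatter) in this assay, a larger step than any measured on the group on the ring nitrogen. This position therefore matters in this series, even though the entering ring keeps the same 5 heavy atoms and no net charge, and differs in holding 2 hetero atoms rather than 3. No measurement here accounts for the size of this step.

From the compounds shown here alone, whether the imidazolyl ring gives a similar step with the acyl group of compound 1 or the bromo of compound 3 remains open. So does how an amine or a carboxylic acid on this phenyl ring would read.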